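This account rests on a few compounds, and the source may have more. Where it says the series, first, only, none or still open, it means among the compounds named here.

Two compounds have been measured in an ADME assay on the whole organism (Rattus norvegicus, strain Sprague-Dawley) for pharmacokinetics, read by LC-MS, with a stated time of 24 h, at a dose of 5 mg/kg by the oral route; a higher number here means more compound in the circulation at the dose given, a lower number less compound in the circulation:

compound 1, `CN1CCC(=C(F)c2cccc(NC(=O)c3ccc(F)cn3)n2)CC1`: 101 nM
compound 2, `CN1CCC(=C(F)c2cccc(NC(=O)c3ccc(Cl)cc3F)n2)CC1`: 61.4 nM

Going by the values given here, the only measured step, a 1.6-fold lower number from compound 1 to compound 2 (0.22 log units; within the scatter), lies within the scatter, so the two numbers cannot be told apart and compound 2 stands level with the other. Compound 3, `CN1CCC(=C(F)c2cccc(NC(=O)c3ccc(Cl)cc3)n2)CC1`, differs from compound 2 by hydrogen in place of fluoro on an aromatic carbon. Among the compounds with values here, no measured step touches this position; the one step known concerned another part of the molecule and was itself within the scatter. For compound 3 no change beyond the scatter is therefore expected in this assay, a 1.0-fold lower number from compound 2 to compound 3 (0.01 log units; within the scatter). Compound 3 is estimated at 60 nM, within a range from 20 nM to 180 nM.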

Compound 3, maximal plasma concentration: 99.2 nM
For compound 3 the middle estimate is 1.7-fold (0.22 log units) below the measured one; the range from low to high includes it.
By their numbers in this assay, from the lowest: compounds 2, 3 and 1 (each within the scatter of the next).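

In this assay, hydrogen in place of fluoro on the aromatic ring gives a 1.6-fold higher number from compound 2 to compound 3 (0.21 log units; within the scatter) and so stays inside the noise of repeat measurements, which means this fluoro shows no readable effect on the number. The other new comparison, 4-chlorophenyl in place of 5-fluoropyridin-2-yl, gives a 1.0-fold lower number from compound 1 to compound 3 (0.01 log units; within the scatter) and leaves compound 3 level with compound 1 as well. No supporting measurement is available to explain these results. Still open, on these data alone, is whether a larger group at this place, such as methoxy, a nitrile or an amine, would move the number beyond the scatter.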